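Compound 4: a methoxyethoxy analogue of compound 3

The source may hold more compounds than are shown below. What is called first, only, known or untested is meant among the compounds shown, and "the series" means these compounds.

Compound 1, `C=CC(=O)Nc1cccc(Nc2ncnc(Nc3ccc(C(=O)N4CCCCC4)cc3)n2)c1`, gives 5140 nM in a functional assay on Raji cells (Homo sapiens) for antiproliferative activity, read by CCK-8 assay, with a stated time of 24 h; a higher number here means a weaker inhibitor, a lower number a stronger inhibitor.
Compound 2, `C=CC(=O)Nc1cccc(Nc2ncnc(Nc3ccc(OC)cc3)n2)c1`, gives 14500 nM in this assay.
Compound 3, `C=CC(=O)Nc1cccc(Nc2ncnc(Nc3ccc(-c4ccc(F)nc4)cc3)n2)c1`, gives 3250 nM in this assay.

Among these three, compound 3 carries the lowest number. Its separation from the others is uneven: a 1.6-fold lower number from compound 1 to compound 3 (0.20 log units; within the scatter), whereas a 4.5-fold lower number from compound 2 to compound 3 (0.65 log units; beyond the scatter). The two measured substituents that are not the fluoropyridinyl thus sit at different distances from compound 3, with a 2.8-fold higher number from compound 1 to compound 2 (0.45 log units; beyond the scatter) between them.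

Compound 4, `C=CC(=O)Nc1cccc(Nc2ncnc(Nc3ccc(OCCOC)cc3)n2)c1`, is built from compound 3 by a single change: 2-methoxyethoxy in place of 6-fluoropyridin-3-yl on an aromatic carbon. Going by the values given here, the step that bears most directly on this change is the one from compound 2 to compound 3, since compound 2 is the only other measured compound with an oxygen-linked substituent at that position, and that step was beyond the scatter. The step from compound 1 to compound 3 is less relevant, as the carbonyl-linked group of compound 1 resembles neither substituent.

On that basis compound 4 is expected to move back toward the number of compound 2, so the step of a 3.1-fold higher number from compound 3 to compound 4 (0.49 log units; beyond the scatter) is estimated to be upward and beyond the scatter. The estimate for compound 4 in this assay is 10000 nM, with a range from 4000 nM to 25000 nM.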

Compound 4, half-maximal inhibitory concentration: 105000 nM
The estimate for compound 4 lay 11-fold (1.02 log units) below the measured number, and the stated range ends below it.
By their numbers in this assay, from the lowest: compounds 3 and 1 (each within the scatter of the next); then compound 2; then compound 4.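

In this assay, the position para to a large group turns out to tolerate far less than compounds 1 to 3 suggested: a 32-fold higher number from compound 3 to compound 4 (1.51 log units; beyond the scatter) is wider than any step among those three, and a 20-fold higher number from compound 1 to compound 4 (1.31 log units; beyond the scatter) likewise exceeds them. The oxygen-linked substituents also do not behave as one class, since lengthening methoxy to 2-methoxyethoxy gives a 7.2-fold higher number from compound 2 to compound 4 (0.86 log units; beyond the scatter), making compound 4 the weakest of the four, with its steps to all the others beyond the scatter. Nothing available accounts for this rise from the added methoxymethyl.

The compounds shown leave open whether the rise follows the length of the chain or its terminal methoxy, a question that an ethoxy group, a 2-hydroxyethoxy group or a chain ending in an amine would help to separate. They also leave open how much of the lower number of compound 3 belongs to the fluorine of its 6-fluoropyridin-3-yl group rather than to the ring itself, which a plain pyridin-3-yl or phenyl group at the same place would test.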